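The source may report more compounds than this note shows. Statements on the series, on what has been measured and on what is new or still open speak of the compounds shown alone.

Measured in a functional assay on HCT-116 cells (Homo sapiens) for inhibition, read by CCK-8 assay, with a stated time of 72 h, tested at 8 uM; on this read-out lower numbers stand for less inhibition of growth and higher numbers for more inhibition of growth at the one concentration tested:
compound 1 `Cc1cc(C)cc(SCc2ccc(/C=C/C(=O)Nc3ccccc3N)cc2)c1`: 4.2%
compound 2 `COc1ccc(SCc2ccc(C(=O)Nc3ccccc3N)cc2)cc1`: 90.1%
compound 3 `CCc1ccc(SCc2ccc(C(=O)Nc3ccccc3N)cc2)cc1`: 79.1%

Compound 1 has the lowest number of the three, beyond the scatter from both others. The unmeasured compound 4 `Nc1ccccc1NC(=O)/C=C/c1ccc(CSc2ccc(C(F)(F)F)cn2)cc1` keeps the core of compound 1 and carries 5-(trifluoromethyl)pyridin-2-yl in place of 3,5-dimethylphenyl on a sulfur. Among the compounds with values here, only one measured step bears on this change, and only loosely: a number 11 percentage points lower from compound 2 to compound 3 (beyond the scatter). That modest step belongs to another core and exchanges a different pair of groups. With compound 1 at 4.2%, there is little room for a fall, so a rise of similar size is expected, with wide uncertainty. The expected step is a number 13.8 percentage points higher from compound 1 to compound 4 (beyond the scatter). For compound 4 the estimate is 18%, with an expected range from 3% to 55%.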

Compound 4, percent growth inhibition at one concentration: 14.9%
Compound 4: middle estimate off by 3.1 percentage points, on the high side; measured number inside the range.
By their numbers in this assay, from the lowest: compound 1; then compound 4; then compound 3; then compound 2.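

On the core of compound 1, the group on the sulfur does move the read-out in this assay: 5-(trifluoromethyl)pyridin-2-yl in place of 3,5-dimethylphenyl gives a number 10.7 percentage points higher from compound 1 to compound 4 (beyond the scatter), the first step measured at this position on this core. The step is modest, and compound 4 still reads only 14.9% on this scale. Nothing available accounts for the step. Going by these compounds, it remains open whether an unsubstituted pyridin-2-yl on the same sulfur would give a similar number, which would help separate the ring nitrogen from the trifluoromethyl group.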